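The compounds below may be only part of what the source reports. "The series", "measured", "known", "first", "only" and "open" are said of these compounds alone.

Within the data shown here, in a functional assay on A549 cells (Homo sapiens) for antiproliferative activity, read by MTT assay, with a stated time of 48 h (a lower number here means a stronger inhibitor, a higher number a weaker inhibitor), compound 3 `N#CC1=C(N)Oc2c(N)cc3nc4ccccc4nc3c2C12C(=O)N(Cc1cnnn1-c1cccc(C(F)(F)F)c1)c1ccccc12` gives 5400 nM, the only numerical reading among the three measured compounds. Compound 1 `N#CC1=C(N)Oc2c(c3nc4ccccc4nc3c3ccccc23)C12C(=O)N(Cc1cnnn1-c1ccc(F)cc1)c1ccccc12` reaches only the limit of the assay, > 50000 nM. Compound 2 `Cc1ccc(-n2nncc2CN2C(=O)C3(C(C#N)=C(N)Oc4c3c3nc5ccccc5nc3c3ccccc43)c3ccccc32)cc1C` likewise stops at the limit, > 50000 nM. Among the measured compounds shown here, the step that the two limits leave unreadable from compound 1 to compound 2 therefore cannot be read, and the only evidence on the measured set is the limit of > 50000 nM in this assay, at which 2 of the 3 values shown sit. For the measured compounds named here, compound 3 thus stands alone as the one compound with a measured potency, and no measured step bears on the change that leads to compound 4 `N#CC1=C(N)Oc2c(N)cc3nc4ccccc4nc3c2C12C(=O)N(Cc1cnnn1-c1ccc([N+](=O)[O-])cc1[N+](=O)[O-])c1ccccc12`. That change is 2,4-dinitrophenyl in place of 3-(trifluoromethyl)phenyl on an aromatic nitrogen. With no readable step in hand, the size of the step in this assay cannot be anchored on anything shown; the account therefore expects compound 4 to land near compound 3, with a wide spread, and allows for the possibility that compound 4 too only reaches the limit. The estimate for compound 4 is 8000 nM, between 2000 nM and 40000 nM. This estimate means an expected step of a 1.5-fold higher number from compound 3 to compound 4 (0.17 log units; within the scatter).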

Compound 4, half-maximal inhibitory concentration: > 50000 nM
Compound 4 ended at the assay's limit; the forecaster's own chance of this, stated with the estimate: 35%; at least 6.2-fold (0.79 log units) between middle value and limit.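

In this assay, the group on the aromatic nitrogen now has a step that can be read, which the earlier pair could not offer, as the step between compound 1 and compound 2 cannot be read. Putting 2,4-dinitrophenyl in place of 3-(trifluoromethyl)phenyl gives an at least 9.2-fold higher number from compound 3 to compound 4 (0.96 log units; beyond the scatter), so with the rest of the structure unchanged, this one position is enough to separate a measured reading from a limit. The size of that step has only a lower bound, and compound 3 remains the only compound with a number, while the limit now takes in most of the set: the limit of > 50000 nM in this assay, at which 3 of the 4 values shown sit.

The compounds shown do not separate what the loss of 3-(trifluoromethyl)phenyl contributes from what the arrival of 2,4-dinitrophenyl contributes, and they do not tell whether either nitro group alone would give the same result. On these data alone, it also remains open how this core would read with an unsubstituted phenyl, a benzyl group, or a phenyl ring carrying an amine or a carboxylic acid on the same nitrogen.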